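Methyl on the Imidazole Carbon: Two Cores, One Change

The source may report more compounds than this note shows. Statements on the series, on what has been measured and on what is new or still open speak of the compounds shown alone.

Measured so far:
Compound 1 `CC(=O)N(C)C(C)C#CCn1ccnc1` — > 100 mg/kg, a limit of the assay, not a number.
Compound 2 `CC(=O)N(C)C(C)C#CCn1cncc1C` — 80 mg/kg.
Compound 3 `CC1CCC(=O)N1CC#CCn1ccnc1` — 20.9 mg/kg.

The read-out throughout is a functional assay on the whole organism for antagonist activity, with Mus musculus as the target; on this read-out lower numbers stand for an effect already at smaller amounts and higher numbers for an effect only at larger amounts of compound. Compound 1 reaches only the limit recorded for it, (the limit of > 100 mg/kg in this assay, at which 1 of the 3 values shown sits). Compound 2 differs from compound 1 by methyl in place of hydrogen on an aromatic carbon, and that change gives an at least 1.2-fold lower number from compound 1 to compound 2 (0.09 log units; that floor lies within the scatter). Compound 3 carries a different core; the difference between the two cores is not broken down here. In this assay compound 3 gives the lowest of the two numbers, and its gap to compound 2 lies beyond the scatter.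

Compound 4 `Cc1cncn1CC#CCN1C(=O)CCC1C` is not yet measured. It differs from compound 3 by methyl in place of hydrogen on an aromatic carbon, the same change that turns compound 1 into compound 2. Since that earlier step, from compound 1 to compound 2, only touched a limit and its floor lies within the scatter, a small gain at most is expected, a 1.4-fold lower number from compound 3 to compound 4 (0.14 log units; within the scatter). Compound 4 is therefore estimated at 15 mg/kg in this assay, with a range of 6 mg/kg to 40 mg/kg.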

Compound 4, dose for half-maximal effect: 14.2 mg/kg
Estimate against measurement, compound 4: 1.1-fold (0.02 log units) above; low and high end bracket the measured number.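

In this assay, among these compounds, methyl in place of hydrogen on an aromatic carbon gives a 1.5-fold lower number from compound 3 to compound 4 (0.17 log units; within the scatter), so on the core of compound 3 this change produces no step that can be read beyond the scatter. Nothing here shows that the change has the same size on both cores, and nothing shows that its size differs between them: the same change on two cores in this assay, an at least 1.2-fold lower number (0.09 log units; that floor lies within the scatter) from compound 1 to compound 2 and a 1.5-fold lower number (0.17 log units; within the scatter) from compound 3 to compound 4; the limit leaves it open whether they differ. Compound 1 gives > 100 mg/kg, which is a limit of the assay and not a number.

The compounds shown leave open whether ethyl, a longer chain, an amine or a carboxylic acid on that aromatic carbon would give a step beyond the scatter in this assay. They also leave open how methyl would read on the other aromatic carbons of the ring, and whether the change would behave in the same way on any core other than these two.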